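A few compounds are considered here, and "the series" means these few. Any claim that something is new, unique, unknown or untested is made for them only; others in the source may bear on it.

In a functional assay on MDA-MB-231 cells (Homo sapiens) for antiproliferative activity, with a stated time of 72 h (on this read-out lower numbers stand for an effect already at smaller amounts and higher numbers for an effect only at larger amounts of compound), compound 1 (`O=C1OCc2cc(N(Cc3ccc(C4CCCCC4)cn3)C(=O)[C@H]3CCN3S(=O)(=O)c3c(F)c(F)c(F)c(F)c3F)ccc21`) gives 900 nM and compound 2 (`CNC(=O)c1ccc(N(Cc2ccc(C3CCCCC3)cn2)C(=O)[C@H]2CCN2S(=O)(=O)c2c(F)c(F)c(F)c(F)c2F)cc1O`) gives 1800 nM as its value. The two differ only in the group on an amide-type nitrogen. Going by the values given here, the only measured step is a 2.0-fold higher number from compound 1 to compound 2 (0.30 log units; within the scatter) and it lies within the usual scatter, so these numbers do not separate compound 2 from compound 1.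

Compound 3 (`O=C1NC(=O)c2cc(N(Cc3ccc(C4CCCCC4)cn3)C(=O)[C@H]3CCN3S(=O)(=O)c3c(F)c(F)c(F)c(F)c3F)ccc21`) has not yet been measured. It keeps the shared core and changes that same group, and the difference from compound 2 reads a group of 11 heavy atoms (8 carbon, 1 nitrogen, 2 oxygen; one five-membered non-aromatic ring with 1 hetero atom, one six-membered aromatic ring of carbon only) in place of a group of 11 heavy atoms (8 carbon, 1 nitrogen, 2 oxygen; one six-membered aromatic ring of carbon only), on an amide-type nitrogen at that nitrogen. The 3-hydroxy-4-(methylcarbamoyl)phenyl group leaves, and the entering group has one five-membered non-aromatic ring with 1 hetero atom, as the group in compound 1 also does.

Among the compounds with values here, the only guide is that single step, a 2.0-fold higher number from compound 1 to compound 2 (0.30 log units; within the scatter) in size, so no change beyond the scatter is expected in this assay for this swap. The expected size of the move is a 1.4-fold lower number from compound 2 to compound 3 (0.14 log units; within the scatter) and no more than that. For compound 3 the estimate is 1300 nM with an expected range from 450 nM to 4000 nM in a measurement.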

Compound 3, half-maximal effective concentration: 1700 nM
Compound 3: middle estimate off by 1.3-fold (0.12 log units), on the low side, and the stated range covers the measured number.
By their numbers in this assay, from the lowest: compounds 1, 3 and 2 (each within the scatter of the next).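

In this assay, putting the group of compound 3, with its five-membered non-aromatic ring, on the amide-type nitrogen in place of the 3-hydroxy-4-(methylcarbamoyl)phenyl group gives a 1.1-fold lower number from compound 2 to compound 3 (0.02 log units; within the scatter), so this swap leaves no readable difference. The comparison with the other group that has a five-membered non-aromatic ring with 1 hetero atom gives a 1.9-fold higher number from compound 1 to compound 3 (0.28 log units; within the scatter), so a ring holding nitrogen as well as oxygen atoms, in compound 3, is not separated from the group of 8 carbon and 2 oxygen atoms in compound 1. Three different groups now sit at this position, including a pair that differs in hydrogen-bond donors, and none of the three compounds can be told apart from the others on these numbers. No measurement is available to explain this flat result.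

On these data alone, it remains open whether any group at this nitrogen can move the number beyond the scatter, for example a plain phenyl ring, or a phenyl ring carrying an amine or a carboxylic acid. These compounds also say nothing about changes elsewhere in the shared core, which stays the same in all three.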